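The source may report more compounds than this note shows. Statements on the series, on what has been measured and on what is new or still open speak of the compounds shown alone.

Measured so far in an ADME assay on MDCK cells (Canis lupus familiaris) for cytotoxicity, read by microscopy, with a stated time of 48 h; a higher number here means that more compound is tolerated, a lower number that less compound is tolerated:
Compound 1 `CCCc1csc(CN[C@@H]2C[C@H]3C[C@@H]([C@H]2C)C3(C)C)c1` gives 12500 nM.
Compound 2 `C[C@H]1[C@H](NCc2cnccn2)C[C@H]2C[C@@H]1C2(C)C` gives > 100000 nM.
Compound 3 `C[C@H]1[C@H](NCc2ccc(-c3ccc(Br)s3)s2)C[C@H]2C[C@@H]1C2(C)C` gives 780 nM.

Compound 2 stands apart from the other two: its entry in this assay is a limit, not a number, so all that is known is that compound 2 sits at the limit of > 100000 nM in this assay, at which 1 of the 3 values shown sits. Compound 1 and compound 3 each return a number, and compound 3 is tolerated less than compound 1, a gap beyond the usual scatter.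

The next compound, compound 4 `Cc1csc(CN[C@@H]2C[C@H]3C[C@@H]([C@H]2C)C3(C)C)n1`, is reached from compound 2 by a single exchange: 4-methyl-1,3-thiazol-2-yl in place of pyrazin-2-yl on a saturated chain carbon bound to an amine nitrogen. Among the compounds with values here, since compound 2 carries only a limit, no measured step can be stated for this change; there is also no measured pair elsewhere in the set that differs in one place alone. Compound 4 keeps the shared core of compound 2 and exchanges one six-membered two-heteroatom aromatic ring for a five-membered one holding sulfur. Compound 1, with its own sulfur-bearing ring, gives 12500 nM, and this is the nearest anchor. Compound 4 is therefore expected to be tolerated somewhat less than the limit of compound 2, with the step from compound 2 to compound 4 estimated as an at least 2.5-fold lower number from compound 2 to compound 4 (0.39 log units; beyond the scatter), though a result that is again only a limit cannot be excluded. The estimate for compound 4 is 40000 nM, with a range from 12500 nM to 100000 nM.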

Compound 4, minimum cytotoxic concentration: > 100000 nM
Compound 4 gave a limit, no number; the forecaster's own chance of this, stated with the estimate: 35%; at least 2.5-fold (0.39 log units) between middle value and limit.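

Compound 2 and compound 4 each return only a limit in this assay, not a number, so no step can be read between them: the limit of > 100000 nM in this assay, at which 2 of the 4 values shown sit.

The compounds shown leave open whether 4-methyl-1,3-thiazol-2-yl in place of pyrazin-2-yl changes tolerance at all, and by how much.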